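Double-bond geometry in a series at the assay limit

The source may report more compounds than this note shows. Statements on the series, on what has been measured and on what is new or still open speak of the compounds shown alone.

In a functional assay on A549 cells (Homo sapiens) for cytotoxicity, read by MTT assay, with a stated time of 72 h (a lower number here means a stronger inhibitor, a higher number a weaker inhibitor), compound 1 `CCCCC(C)C/C(=C/[C@@]1(CC)OC(=O)C[C@@H]1O)CC` gives > 100000 nM as a limit and not a number. Compound 2 `CCCCC(C)Cc1cc(CC)c(CC(=O)O)o1` gives > 100000 nM as a limit too. Compound 3 `CCCCC(C)C/C(=C\[C@@]1(CC)OC(=O)C[C@@H]1O)CC` differs from compound 1 in one place: the two compounds have the same atoms and bonds; at least one stereo element is drawn with a configuration in one of them and without one in the other: 1 of 4 stereo elements differ; a double bond is drawn E in compound 1 and Z in compound 3 and so the double bond is drawn E in compound 1 and Z in compound 3. Going by the values given here, no measured step covers such a change. In this assay the estimated step of a number no higher from compound 1 to compound 3 (the limit leaves the size open) is expected to stay within the scatter. The estimate for compound 3 is 100000 nM with an expected range from 40000 nM to 200000 nM and another limit is likely.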

Compound 3, half-maximal inhibitory concentration: > 100000 nM
Compound 3: a limit, no number; the forecaster's own chance of this, stated with the estimate: 80%; the middle value sits exactly at the limit.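

No step can be read between compound 1 and compound 3, as both give only a limit in this assay: the limit of > 100000 nM in this assay, at which 3 of the 3 values shown sit.

The compounds shown leave open whether drawing the double bond E or Z makes any difference in this assay.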